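The compounds below may be only part of what the source reports. "The series", "measured", "known", "first", "only" and "open" are said of these compounds alone.

Measured compounds in a functional assay on L1210 cells (Mus musculus) for antiproliferative activity, read by MTT assay, with a stated time of 72 h; on this read-out lower numbers stand for stronger inhibition and higher numbers for weaker inhibition:
compound 1, `COc1ccccc1C1OC(c2cc(OC)c(OC)c(OC)c2)=NN1C(C)=O` — 48000 nM
compound 2, `COc1cc(C2=NN(C(C)=O)C(c3ccccc3)O2)cc(OC)c1OC` — 6400 nM
compound 3, `COc1ccc(C2=NN(C(C)=O)C(c3cc(OC)c(OC)c(OC)c3)O2)cc1` — 500 nM

Compound 3 gives the lowest number of the three. Compound 1 and compound 3 have the same atoms joined differently; the difference between the two cores is not broken down here. From compound 1 to compound 2 the change is hydrogen in place of methoxy on an aromatic carbon, and it gave a 7.5-fold lower number from compound 1 to compound 2 (0.88 log units; beyond the scatter).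

Compound 4, `COc1ccc(C2=NN(C(C)=O)C(c3cc(OC)cc(OC)c3)O2)cc1`, is not yet measured. It differs from compound 3 by hydrogen in place of methoxy on an aromatic carbon. This is the same kind of change as that from compound 1 to compound 2, but at a different place: there the carbon was ortho to a large group, here it is ortho to two methoxy groups and para to a large group. Because a 7.5-fold lower number from compound 1 to compound 2 (0.88 log units; beyond the scatter) lowered the number at a different place, that step is no firm guide here. For compound 4 a step of a 3.0-fold higher number from compound 3 to compound 4 (0.48 log units; beyond the scatter) is expected, and its estimated value in this assay is 1500 nM, between 300 nM and 8000 nM.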

Compound 4, half-maximal inhibitory concentration in the L1210 assay: 500 nM
Estimate against measurement, compound 4: 3.0-fold (0.48 log units) above, and the stated range covers the measured number.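

In the L1210 assay, hydrogen in place of methoxy gave no change at the digits printed from compound 3 to compound 4 (within the scatter), so the size of this step does not carry from one core to the other: the same change on two cores in the L1210 assay, a 7.5-fold lower number (0.88 log units; beyond the scatter) from compound 1 to compound 2 and no change at the digits printed (within the scatter) from compound 3 to compound 4, 7.5-fold (0.88 log units) apart, beyond the scatter of two such steps. Among the compounds shown here, each core supplies only one pair and the methoxy leaves a different place in each, so these data cannot separate the effect of the core from that of the place. For the compounds shown here, in a physicochemical assay for solubility, at pH 7.4 (on this read-out higher numbers stand for higher solubility and lower numbers for lower solubility), compound 3 gives 257000 nM and compound 4 gives 94000 nM, so the change on the core of compound 3 gave a lower number, with no matching pair on the other core: the measured solubility of compound 3, 257000 nM, and of compound 4, 94000 nM, a 2.7-fold lower number (0.44 log units; beyond the scatter).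

From the compounds shown here alone, what an amine or a carboxylic acid on that aromatic carbon would do in the L1210 assay and the physicochemical assay remains open. Also open, going by these compounds, is whether the same change at one place gives the same step on both cores.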